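The compounds below may be only part of what the source reports. "The series", "measured", "known", "first", "only" and "open" are said of these compounds alone.

Working notes on the series. Compound 1 `CCCCCCCCCCCCCCCCCCCCCC(=O)OC[C@H]1O[C@@H](n2ccc(N)nc2=O)[C@@H](O)[C@@H]1O` and compound 2 `C=CCCCCCCCCC(=O)O[C@H]1[C@H](O)[C@H](n2ccc(N)nc2=O)O[C@@H]1CO` share the same core and differ in the chain attached to it and in where that chain sits. In a functional assay on HeLa cells (Homo sapiens) for cytotoxicity, read by cell counting, with a stated time of 48 h (on this read-out higher numbers stand for an effect only at larger amounts of compound and lower numbers for an effect already at smaller amounts), compound 1 gives 0.04 ug/mL. In this assay, among the compounds with values here, compound 2 gives 0.05 ug/mL, the highest of the two numbers so far; the gap to compound 1 is within the scatter, so the two read as equivalent.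

Compound 3 `CCCCCCCCC(=O)O[C@H]1[C@H](O)[C@H](n2ccc(N)nc2=O)O[C@@H]1CO` is the next member: relative to compound 2 the change is hydrogen in place of vinyl on a saturated chain carbon, eight bonds along the chain from a carbonyl carbon, so the chain ends in a saturated carbon and is shorter by the counted atoms. Within the data shown here, no step between measured compounds of this kind exists, so the expectation rests on the closeness of compound 1 and compound 2 alone. For compound 3 in this assay a step of a 1.4-fold higher number from compound 2 to compound 3 (0.15 log units; within the scatter) is expected, toward a somewhat higher number but not clearly beyond the scatter. Compound 3 is estimated at 0.07 ug/mL, with a range from 0.03 ug/mL to 0.2 ug/mL.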

Compound 3, concentration for half-maximal effect: 0.05 ug/mL
For compound 3 the middle estimate is 1.4-fold (0.15 log units) above the measured one; the measured number falls inside the stated range.
By their numbers in this assay, from the lowest: compounds 1, 2 and 3 (each within the scatter of the next).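

Within the data shown here, this is the first step that isolates a single place: no change at the digits printed from compound 2 to compound 3 (within the scatter) in this assay, with hydrogen in place of vinyl on a saturated chain carbon, eight bonds along the chain from a carbonyl carbon. At this place, then, the read-out tolerates the loss of the vinyl and its double bond, and the chain can end in a saturated carbon with no difference beyond the scatter. No measurement available here accounts for this result.

The compounds shown leave open whether a longer saturated chain, an amine or a carboxylic acid at this place would move the number beyond the scatter. They also leave open what moving the same chain to another attachment point on the shared core would do, with the chain itself held constant.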